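Capping the hydroxyl of compound 3 with a carbamoyl group

The source may report more compounds than this note shows. Statements on the series, on what has been measured and on what is new or still open speak of the compounds shown alone.

Measured compounds:
compound 1 `OC1C[C@@H]2CCCC[C@@H]2[C@H]1/C=C/c1ccc(-c2cccc(F)c2)cn1` gives 220 nM in an assay on cell membranes for displacement of a labelled ligand from proteinase-activated receptor 1 (Homo sapiens), read by scintillation counting, with a stated time of 60 min; on this read-out lower numbers stand for stronger inhibition and higher numbers for weaker inhibition.
compound 2 `COC(=O)NC1C[C@@H]2CCCC[C@@H]2[C@H]1/C=C/c1ccc(-c2cccc(F)c2)cn1` gives 980 nM in this assay.
compound 3 `CC1(O)C[C@@H]2CCCC[C@@H]2[C@H]1/C=C/c1ccc(-c2cccc(F)c2)cn1` gives 33 nM in this assay.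

Compound 3 has the lowest number of the three, and its gap to each of the other two is beyond the scatter, so it is the strongest binder among them. It differs from compound 1 by a single change, and that step was a 6.7-fold lower number from compound 1 to compound 3 (0.82 log units; beyond the scatter).

Compound 4 `CC1(OC(N)=O)C[C@@H]2CCCC[C@@H]2[C@H]1/C=C/c1ccc(-c2cccc(F)c2)cn1` is the next one to consider. The change from compound 3 is carbamoyl in place of hydrogen on an oxygen on a saturated carbon; cut one bond further out, it reads as hydroxy to carbamoyloxy.

One measured step resembles this: going from compound 1 to compound 2 also replaced the free hydroxy with a larger group carrying a carbonyl and a nitrogen, and that step was a 4.5-fold higher number from compound 1 to compound 2 (0.65 log units; beyond the scatter). It is not the same change, since there the oxygen itself was exchanged, but it is the closest guide available. A weakening of similar or somewhat smaller size is therefore expected here, so compound 4 is estimated at 90 nM, within 30 nM to 270 nM, which means an expected step of a 2.7-fold higher number from compound 3 to compound 4 (0.44 log units; beyond the scatter).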

Compound 4, half-maximal inhibitory concentration: 2.7 nM
For compound 4 the middle estimate is 33-fold (1.52 log units) above the measured one; measured number below the stated range.
By their numbers in this assay, from the lowest: compound 4; then compound 3; then compound 1; then compound 2.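

In this assay, the free hydroxy of compound 3 is not required for binding, as capping its oxygen with carbamoyl gives a 12-fold lower number from compound 3 to compound 4 (1.09 log units; beyond the scatter) and the larger group is more than tolerated at this position. The earlier guide pointed the other way: a different group containing a carbonyl and a nitrogen gave a 4.5-fold higher number from compound 1 to compound 2 (0.65 log units; beyond the scatter), so the presence of those two features does not set the direction of the step across these compounds, although that earlier change also exchanged the oxygen and started from a compound without the methyl. No measurement offered here explains the gain in compound 4.

As far as these compounds go, the carbamoyloxy group appears only in compound 4, alongside the methyl, so it remains open whether the same gain would appear on the core of compound 1, which lacks that methyl. From the compounds shown here alone, it is also open how closely the result depends on the carbamoyl itself, as an acetyl or an N-methylcarbamoyl group on the same oxygen would show.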